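A longer chain on a compound at the assay limit

The source may hold more compounds than are shown below. What is called first, only, known or untested is meant among the compounds shown, and "the series" means these compounds.

In a functional assay on SW480 cells (Homo sapiens) for antiproliferative activity, read by MTT assay, with a stated time of 48 h (a higher number here means a weaker inhibitor, a lower number a stronger inhibitor), compound 1 (`CCCC(CCO)n1cnc2c(Cl)nc(F)nc21`) gives 17200 nM. Compound 2 (`CCCC(CCO)n1cnc2c(Cl)ncnc21`) gives only a limit, > 50000 nM, and not a true number. Compound 3 (`CCCCCCC(CCO)n1cnc2c(OC)ncnc21`) likewise gives only a limit, > 50000 nM. Compound 2 therefore stands at the limit of > 50000 nM in this assay, at which 2 of the 3 values shown sit.

Compound 4 (`CCCCCCCCC(CCO)n1cnc2c(Cl)ncnc21`) has pentyl in place of hydrogen on a saturated chain carbon, four bonds along the chain from an aromatic nitrogen. Within the data shown here, no measured step covers this change. The only one available, an at least 2.9-fold higher number from compound 1 to compound 2 (0.46 log units; beyond the scatter), is hydrogen in place of fluoro on an aromatic carbon. It is a different change, so it offers only a rough guide to how large a step can be in this series. A modest move toward a stronger inhibitor in this assay is expected, of similar size, although another limit would be no surprise. The expected change is an at least 1.6-fold lower number from compound 2 to compound 4 (0.22 log units; that floor lies within the scatter). Compound 4 is estimated at 30000 nM, with an expected range of 9000 nM to 60000 nM.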

Compound 4, half-maximal inhibitory concentration: 1370 nM
Compound 4: middle estimate off by 22-fold (1.34 log units), on the high side, and the stated range ends above it.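

In this assay, the saturated chain carbon four bonds along the chain from an aromatic nitrogen turns out to be a place where one change moves the read-out a long way: pentyl in place of hydrogen gives an at least 36-fold lower number from compound 2 to compound 4 (1.56 log units; beyond the scatter). Among these compounds, the earlier step concerned an aromatic carbon, so this is the first measured change on the chain, and it takes the compound from an assay limit to a true number. The full size of the step stays unknown, and the printed figure is only a floor: the limit of > 50000 nM in this assay, at which 2 of the 4 values shown sit.

A single pair cannot show whether the effect rises steadily with chain length, or whether a shorter ethyl or a longer chain than this one would do as well. It also leaves open how an amine or a carboxylic acid would behave at this place.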